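This account rests on a few compounds, and the source may have more. Where it says the series, first, only, none or still open, it means among the compounds named here.

Compound 2 `COc1cc(C#N)ccc1Oc1nc(Nc2ccc(C#N)cc2)nc2ccccc12` carries a 4-cyano-2-methoxyphenyl on the oxygen of the shared core. In an ADME assay on MT4 cells (Homo sapiens) for cytotoxicity, read by MTT assay, with a stated time of 4 days (on this read-out lower numbers stand for higher toxicity in this test and higher numbers for lower toxicity in this test), compound 2 gives only a limit, >= 140000 nM, so where it stands among the measured compounds cannot be read. Compound 1 `Cc1cccc(Oc2nc(Nc3ccc(C#N)cc3)nc3ccccc23)c1` gives 355000 nM in this assay, and compound 3 `COc1cc(C#N)cc(Cl)c1Oc1nc(Nc2ccc(C#N)cc2)nc2ccccc12` gives 220000 nM. Compound 4 `Cc1cc(Br)cc(Br)c1Oc1nc(Nc2ccc(C#N)cc2)nc2ccccc12` differs from compound 2 by 2,4-dibromo-6-methylphenyl in place of 4-cyano-2-methoxyphenyl on an oxygen on an aromatic ring. The two measured steps that touch compound 2 are a step that the limit leaves unreadable from compound 1 to compound 2 and a step that the limit leaves unreadable from compound 2 to compound 3, both hidden by the limit of >= 140000 nM in this assay, at which 1 of the 3 values shown sits. No readable step is therefore available for this change, and nothing beyond the scatter is expected. Compound 4 is expected at 200000 nM, between 70000 nM and 500000 nM, which means an estimated step that the limit leaves unreadable from compound 2 to compound 4.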

Compound 4, half-maximal cytotoxic concentration: 150000 nM
For compound 4 the middle estimate is 1.3-fold (0.12 log units) above the measured one, within the range that was stated.
By their numbers in this assay, from the lowest: compounds 4, 3 and 1 (each within the scatter of the next, the first and the last beyond it).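

In this assay, 2,4-dibromo-6-methylphenyl in place of 3-methylphenyl on the oxygen gives a 2.4-fold lower number from compound 1 to compound 4 (0.37 log units; beyond the scatter). Among these compounds, this is the only readable step at this position, and it shows that changing the group on the oxygen can shift this read-out, though modestly. The step from compound 2 to compound 4 cannot be read, since compound 2 gives only a limit: the limit of >= 140000 nM in this assay, at which 1 of the 4 values shown sits.

The compounds shown leave open whether the two bromines alone account for this step. They also leave open how an amine or a carboxylic acid on this phenyl would read in this assay.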